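A Sulfur Substituent Added to an Inactive Core

The source may hold more compounds than are shown below. What is called first, only, known or untested is meant among the compounds shown, and "the series" means these compounds.

Compound 2, `COc1cc(-c2nnc(S)n2-c2ccc(N(C)C)cc2)cc(OC)c1OC`, was examined in a functional assay on HT-29 cells (Homo sapiens) for inhibition, read by MTT assay, with a stated time of 48 h; a higher number here means a weaker inhibitor, a lower number a stronger inhibitor. In this assay compound 2 returned > 60000 nM, which is a limit of the assay and not a measured number. Compound 1, `COc1ccc(-n2c(SCC(=O)C3CC3)nnc2-c2cc(OC)c(OC)c(OC)c2)cc1`, was also tested; in this assay compound 1 returned > 60000 nM, again a limit. Compound 3, `COc1ccc(NC(=O)CSc2nnc(-c3cc(OC)c(OC)c(OC)c3)n2-c2ccc(N(C)C)cc2)cc1`, differs from compound 2 by ((4-methoxyphenyl)carbamoyl)methyl in place of hydrogen on a sulfur. Because (the limit of > 60000 nM in this assay, at which 2 of the 2 values shown sit), nothing beyond the scatter is expected from this change. The expected step is a number no higher from compound 2 to compound 3 (the limit leaves the size open). Compound 3 is therefore estimated at 60000 nM, with a range from 15000 nM to 150000 nM.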

Compound 3, half-maximal inhibitory concentration: 51400 nM
Compound 3: the middle estimate sits 1.2-fold (0.07 log units) above what was measured; the measured number falls inside the stated range.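

In this assay compound 3 gives 51400 nM, the first actual measurement among these compounds rather than a limit. Placing ((4-methoxyphenyl)carbamoyl)methyl in place of hydrogen on a sulfur gives an at least 1.1-fold lower number from compound 2 to compound 3 (0.06 log units; that floor lies within the scatter). The true size of this step stays open because compound 2 is known only as a limit: the limit of > 60000 nM in this assay, at which 2 of the 3 values shown sit.

The compounds shown leave open how a small methyl, a longer carbon chain or a carboxylic acid on the same sulfur would read in this assay. They also do not separate the contribution of the aromatic ring from that of the amide.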